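Aryl change at one place on the shared core

A few compounds are considered here, and "the series" means these few. Any claim that something is new, unique, unknown or untested is made for them only; others in the source may bear on it.

Measured in a functional assay on NCI-H460 cells (Homo sapiens) for antiproliferative activity, read by MTT assay, with a stated time of 48 h; on this read-out lower numbers stand for stronger inhibition and higher numbers for weaker inhibition:
compound 1 `COc1cccc(-c2nc3cccc(-c4cc(OC)c(OC)c(OC)c4)c3o2)c1`: > 25000 nM
compound 2 `COc1cc(-c2cccc3nc(-c4ccc(F)cc4)oc23)cc(OC)c1OC`: 8700 nM

The entry for compound 1 is a limit: > 25000 nM. Going by the values given here, compound 2, at 8700 nM, holds the only actual number so far. Compound 3 `COc1cc(-c2nc3cccc(-c4cc(OC)c(OC)c(OC)c4)c3o2)ccc1O` changes the same place: 4-hydroxy-3-methoxyphenyl in place of 4-fluorophenyl on an aromatic carbon. Among the compounds with values here, the one measured step there is an at least 2.8-fold lower number from compound 1 to compound 2 (0.45 log units; beyond the scatter). The 4-hydroxy-3-methoxyphenyl brings back a methoxy group like that of compound 1, so a small loss in this assay, not beyond the scatter, is expected. The estimated step is a 1.1-fold higher number from compound 2 to compound 3 (0.06 log units; within the scatter). For compound 3 the estimate is 10000 nM, with an expected range of 3000 nM to 25000 nM.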

Compound 3, half-maximal inhibitory concentration: 2000 nM
The estimate for compound 3 lay 5.0-fold (0.70 log units) above the measured number; measured number outside the range, below it.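

In this assay this place on the shared core turns out to accept more than the 4-fluorophenyl: the 4-hydroxy-3-methoxyphenyl gives a 4.4-fold lower number from compound 2 to compound 3 (0.64 log units; beyond the scatter), so a methoxy group on this aryl does not by itself cost activity. A single hydroxy in place of hydrogen on the 3-methoxyphenyl gives an at least 12-fold lower number from compound 1 to compound 3 (1.09 log units; beyond the scatter). That step is only a bound, as compound 1 is recorded as a limit of the assay and not as a number: the limit of > 25000 nM in this assay, at which 1 of the 3 values shown sits.

Going by these compounds, it remains open whether the hydroxy needs the methoxy group alongside it. On these data alone, it is also open whether an amine or a carboxylic acid on this aryl would match compound 3.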